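Aryl Hydrazone Swap on a Diaryl Ether Semicarbazide Scaffold

The source may report more compounds than this note shows. Statements on the series, on what has been measured and on what is new or still open speak of the compounds shown alone.

Of the compounds shown here, three sharing one core have been tested in a functional assay on NCI-H460 cells (Homo sapiens) for cytotoxicity, read by MTT assay, with a stated time of 72 h; a higher number here means a weaker inhibitor, a lower number a stronger inhibitor. Compound 1 `CN(C)CCn1cnnc1-c1cc(Oc2ccc(NC(=O)N/N=C/c3c(Cl)cccc3Cl)cc2F)ccn1` gives 350 nM in this assay, compound 2 `COc1ccc(/C=N/NC(=O)Nc2ccc(Oc3ccnc(-c4nncn4CCN(C)C)c3)c(F)c2)c(OC)c1` gives 1570 nM, and compound 3 `Cn1ncnc1-c1cc(Oc2ccc(NC(=O)N/N=C/c3ccccc3)cc2F)ccn1` gives 52200 nM. Compound 2 thus stands second highest of the three numbers, with compound 1 as its nearest neighbour at a lower value and compound 3 far above it.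

Among the compounds with values here, the only single-point step measured so far is a 4.5-fold higher number from compound 1 to compound 2 (0.65 log units; beyond the scatter), a modest rise when the aryl group on the hydrazone carbon is exchanged. Compound 4 `CN(C)CCn1cnnc1-c1cc(Oc2ccc(NC(=O)N/N=C/c3ccc(F)cc3)cc2F)ccn1` follows the same kind of exchange from compound 2: 4-fluorophenyl in place of 2,4-dimethoxyphenyl on a carbon with a double bond to nitrogen.

Compound 3 carries an unsubstituted phenyl at that position but differs from compound 4 elsewhere too, so its value cannot be read as a direct step; it only shows that a plain phenyl variant of the series sits far higher than compounds 1 and 2. Given that aryl swaps at this carbon moved the number modestly between compound 1 and compound 2, a step of a 1.9-fold higher number from compound 2 to compound 4 (0.28 log units; within the scatter) is expected, leaning toward a higher number. Compound 4 is therefore estimated at 3000 nM, with a range from 600 nM to 15000 nM.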

Compound 4, half-maximal inhibitory concentration: 1980 nM
Compound 4: the middle estimate sits 1.5-fold (0.18 log units) above what was measured; the measured number falls inside the stated range.
By their numbers in this assay, from the lowest: compound 1; then compounds 2 and 4 (each within the scatter of the next); then compound 3.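

In this assay, the exchange of 2,4-dimethoxyphenyl for 4-fluorophenyl on a carbon with a double bond to nitrogen gives a small step (a 1.3-fold higher number from compound 2 to compound 4 (0.10 log units; within the scatter)), so these two groups cannot be told apart here, even though they share only the six-membered aromatic ring of carbon and differ in their other atoms and in their hydrogen-bond acceptors. Measured against the 2,6-dichlorophenyl group of compound 1, the 4-fluorophenyl group gives a step beyond the scatter (a 5.7-fold higher number from compound 1 to compound 4 (0.75 log units; beyond the scatter)), as the 2,4-dimethoxyphenyl group did (a 4.5-fold higher number from compound 1 to compound 2 (0.65 log units; beyond the scatter)), so among these three aryl groups on the same core, only 2,6-dichlorophenyl stands apart, with the lower number. Nothing available bears on why this group separates from the other two.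

The compounds shown leave open whether both chlorines of that group are needed, or whether a single chlorine, a bromine or a methyl group on the phenyl ring would give a similar number. They also do not show how an amine or a carboxylic acid on that ring would read, and compound 3 differs from the others in more than one place, so it cannot settle what an unsubstituted phenyl does on this core.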